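Compound 4: One Methoxy Group Moved, Inhibition Estimated

This account rests on a few compounds, and the source may have more. Where it says the series, first, only, none or still open, it means among the compounds named here.

Compound 1 `COC(=O)c1cc(-n2cc(-c3ccc(OC)cc3)nn2)ccc1O` is the reference point of this small set. In a functional assay on CCRF-CEM cells (Homo sapiens) for inhibition, read by MTT assay, with a stated time of 2 days, tested at 10 uM (on this read-out higher numbers stand for more inhibition at the one concentration tested (going by the name of the read-out) and lower numbers for less inhibition), compound 1 gives 16%, the highest of the three numbers in hand. Compound 2 `COc1ccc(-c2cn(-c3ccc(O)c(C(=O)Nc4cccc(C(F)(F)F)c4)c3)nn2)cc1` gives 12% and compound 3 `COc1ccc(-c2cn(-c3ccc(O)c(C(=O)OCCCc4ccccc4)c3)nn2)cc1` gives 5%. The step of a number 4 percentage points lower from compound 1 to compound 2 (within the scatter) lies within the scatter, whereas a number 11 percentage points lower from compound 1 to compound 3 (beyond the scatter) is modest but beyond it; the step of a number 7 percentage points lower from compound 2 to compound 3 (within the scatter) is again within the scatter.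

Compound 4 `COC(=O)c1cc(-n2cc(-c3ccccc3OC)nn2)ccc1O` has not yet been measured. It differs from compound 1 by 2-methoxyphenyl in place of 4-methoxyphenyl on an aromatic carbon; the change sits on an aromatic carbon of a five-membered aromatic ring with 3 nitrogen, next to the ring nitrogen. All three measured steps alter the carbonyl carbon or the saturated chain carbon bound to an oxygen next to a carbonyl group, so none of them bears directly on this change, and even the largest of them is only modest. Within the data shown here, with no measured step pointing either way, compound 4 is expected to sit close to compound 1, and the step of a number 2 percentage points lower from compound 1 to compound 4 (within the scatter) is estimated to fall within the scatter. Compound 4 is therefore expected to give about 14% in this assay, most likely between 2% and 28%.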

Compound 4, a percentage reported as inhibition, at one concentration (the size of the read-out at that concentration, not a potency): 6%
Compound 4: the middle estimate sits 8 percentage points above what was measured; the measured number falls inside the stated range.
By their numbers in this assay, from the lowest: compounds 3, 4, 2 and 1 (each within the scatter of the next, the first and the last beyond it).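

Among these compounds, compound 4 gives the first reading on the aryl group at this place, on an aromatic carbon of a five-membered aromatic ring with 3 nitrogen, since the earlier steps all changed the carbonyl side of the molecule. In this assay, 2-methoxyphenyl in place of 4-methoxyphenyl gives a number 10 percentage points lower from compound 1 to compound 4 (within the scatter), so this rearrangement of the same atoms, with the same heavy-atom, donor and acceptor counts in both groups, does not separate the two compounds on this read-out. Nothing among the data given offers an explanation for the size of this step.

As far as these compounds go, it remains open whether other groups at this place, such as an unsubstituted phenyl, a hydroxyl in place of the methoxy or a longer ethoxy chain, would give a step beyond the scatter, and whether 2-methoxyphenyl would behave in the same way alongside the (3-(trifluoromethyl)phenyl)amino of compound 2 or the 3-phenylpropoxy of compound 3. With a single concentration tested, the numbers also leave open how these compounds would compare across a range of concentrations.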